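The source may hold more compounds than are shown below. What is called first, only, known or untested is meant among the compounds shown, and "the series" means these compounds.

Compound 1 `CCOC(=O)c1c(-c2cccc(OC)c2)[nH]c2cc(OC)ccc2c1=O`: > 100000 nM (a limit)
Compound 2 `CCOC(=O)c1c(-c2ccc(Cl)c(Cl)c2)[nH]c2cc(OC)ccc2c1=O`: 17000 nM

Among the compounds with values here, in a physicochemical assay for solubility, in phosphate buffer, at pH 7.4 (on this read-out lower numbers stand for lower solubility and higher numbers for higher solubility), compound 2 gives 17000 nM, the only actual number so far. The value for compound 1 is a limit. Compound 3 `CCOC(=O)c1c(-c2cccc(Cl)c2)[nH]c2cc(OC)ccc2c1=O` differs from compound 2 by one change, hydrogen in place of chloro on an aromatic carbon. Within the data shown here, one measured step bears on this, an at least 5.8-fold lower number from compound 1 to compound 2 (0.76 log units; beyond the scatter), with 3,4-dichlorophenyl in place of 3-methoxyphenyl on the same carbon. Going from 3,4-dichlorophenyl to 3-chlorophenyl should partly reverse that step, so a modest rise in this assay is expected. The expected step is a 2.4-fold higher number from compound 2 to compound 3 (0.37 log units; beyond the scatter). For compound 3 the estimated value is 40000 nM, with an expected range of 20000 nM to 90000 nM.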

Compound 3, solubility: 58000 nM
Estimate against measurement, compound 3: 1.5-fold (0.16 log units) below; low and high end bracket the measured number.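

In this assay, hydrogen in place of chloro alone gives a 3.4-fold higher number from compound 2 to compound 3 (0.53 log units; beyond the scatter), so a change at this one position, para to a large group, is enough to move the number beyond the scatter, which the earlier pair, differing at two ring positions, could not separate. Chloro in place of methoxy on an aromatic carbon gives an at least 1.7-fold lower number from compound 1 to compound 3 (0.23 log units; that floor lies within the scatter), and since that floor lies within the scatter, this step does not settle whether the swap matters. Compound 1 stands at a limit, not a number: the limit of > 100000 nM in this assay, at which 1 of the 3 values shown sits. Still open, as far as these compounds go, is how an amine or a carboxylic acid on this ring would read in this assay.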